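Swapping an Isopropylsulfonyl for a Cyano Group

This account rests on a few compounds, and the source may have more. Where it says the series, first, only, none or still open, it means among the compounds named here.

Compound 2 `C=CC(=O)Nc1cc(Nc2ncc(Cl)c(Nc3ccccc3S(=O)(=O)C(C)C)n2)c(OC)cc1N1CCN(C(C)C)CC1` was tested in a functional assay on NCI-H1975 cells (Homo sapiens) for inhibition, read by CellTiter-Glo, with a stated time of 72 h (on this read-out lower numbers stand for stronger inhibition of growth and higher numbers for weaker inhibition of growth), where compound 2 gives 25 nM. Among the two measured numbers this is the highest; its nearest neighbour is compound 1 `C=CC(=O)Nc1cc(Nc2ncc(Cl)c(Nc3ccccc3S(=O)(=O)C(C)C)n2)c(OC)cc1N1CCCN(C)CC1`, which in this assay gives 15 nM, and the step of a 1.7-fold higher number from compound 1 to compound 2 (0.22 log units; within the scatter) lies within the scatter. Compound 3 `C=CC(=O)Nc1cc(Nc2ncc(Cl)c(Nc3ccccc3C#N)n2)c(OC)cc1N1CCN(C(C)C)CC1` is not yet measured and differs from compound 2 in one place: cyano in place of isopropylsulfonyl on an aromatic carbon. Within the data shown here, the only measured step alters a different part of the molecule and so says nothing about this change; no measured pair shows what the exchange of isopropylsulfonyl for cyano does in this assay. Without such a precedent the expected step of a 2.4-fold higher number from compound 2 to compound 3 (0.38 log units; beyond the scatter) is uncertain and is estimated with a wide range. For compound 3 the expected number in this assay is 60 nM, with a range from 15 nM to 300 nM.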

Compound 3, concentration for 50% growth inhibition: 430 nM
Beside the measured number, compound 3's estimate is 7.2-fold (0.86 log units) below it, outside the stated range (above it).
By their numbers in this assay, from the lowest: compounds 1 and 2 (each within the scatter of the next); then compound 3.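

In this assay the exchange of 2-(isopropylsulfonyl)phenyl for 2-cyanophenyl produces a 17-fold higher number from compound 2 to compound 3 (1.24 log units; beyond the scatter) and thus weakens growth inhibition clearly. This aromatic carbon, ortho to a large group, therefore does not tolerate this exchange, whereas the amine exchange elsewhere on the molecule gave only a 1.7-fold higher number from compound 1 to compound 2 (0.22 log units; within the scatter) and stayed within the scatter. The data offer no measured property that accounts for the size of the new step.

The compounds shown leave open whether the sulfonyl or its isopropyl group matters more, since a methylsulfonyl group, a primary sulfonamide or a carboxamide at this position would separate the two. They also leave open whether cyano would cost as much with the 4-methyl-1,4-diazepan-1-yl group in place of 4-isopropylpiperazin-1-yl.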